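This account rests on a few compounds, and the source may have more. Where it says the series, first, only, none or still open, it means among the compounds named here.

Measured so far:
compound 1 `Cc1ncc([N+](=O)[O-])n1CCSc1nnc(-c2ccccc2)o1` gives 20500 nM
compound 2 `Cc1cccc(-c2nnc(SCCn3c([N+](=O)[O-])cnc3C)o2)c1O` gives 19900 nM

Among the measured compounds shown here, in a functional assay on MCF7 cells (Homo sapiens) for cytotoxicity, read by MTT assay, with a stated time of 48 h (on this read-out higher numbers stand for weaker inhibition and lower numbers for stronger inhibition), compound 2 stands at 19900 nM and lies within the scatter of compound 1 at 20500 nM on the only two numbers available. The change to compound 3 `Cc1ccc(-c2nnc(SCCn3c([N+](=O)[O-])cnc3C)o2)c(O)c1` is 2-hydroxy-4-methylphenyl in place of 2-hydroxy-3-methylphenyl on an aromatic carbon and puts 2-hydroxy-4-methylphenyl in place of 2-hydroxy-3-methylphenyl on an aromatic carbon. For the measured compounds named here, the one measured step (a 1.0-fold lower number from compound 1 to compound 2 (0.01 log units; within the scatter)) put 2-hydroxy-3-methylphenyl in place of phenyl and stayed within the scatter, so no larger step has been seen with these groups. The estimated step in this assay (a 1.0-fold lower number from compound 2 to compound 3 (0.02 log units; within the scatter)) is expected to stay within the scatter, with no direction favoured. Compound 3 is therefore expected near 19000 nM (estimated range 9000 nM to 40000 nM).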

Compound 3, half-maximal inhibitory concentration: 23500 nM
For compound 3 the middle estimate is 1.2-fold (0.09 log units) below the measured one; the range from low to high includes it.
By their numbers in this assay, from the lowest: compounds 2, 1 and 3 (each within the scatter of the next).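

In this assay the swap of 2-hydroxy-3-methylphenyl for 2-hydroxy-4-methylphenyl gives a 1.2-fold higher number from compound 2 to compound 3 (0.07 log units; within the scatter) and the swap of phenyl for 2-hydroxy-4-methylphenyl gives a 1.1-fold higher number from compound 1 to compound 3 (0.06 log units; within the scatter) on this same aromatic carbon. The new point is that moving the methyl group around the phenyl ring, not only adding the hydroxy and methyl groups, leaves the number within the scatter. No available evidence accounts for this flat result. Going by these compounds, whether an amine, a carboxylic acid or a longer chain at this position would give a step beyond the scatter remains open.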